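Replacing a Thiophene Amide with an Acetamide

The source may report more compounds than this note shows. Statements on the series, on what has been measured and on what is new or still open speak of the compounds shown alone.

The three measured compounds, all tested in a functional assay on HUVEC cells (Homo sapiens) for inhibition, tested at 5 ug/mL; on this read-out lower numbers stand for a weaker effect and higher numbers for a stronger effect at the one concentration tested:
Compound 1, `COc1cc(/C=C/C(=O)c2cccc(NC(=O)C(C)C)c2)ccc1O`: in this assay compound 1 gives 51%.
Compound 2, `COc1cc(/C=C/C(=O)c2cccc(NC(=O)c3ccccc3)c2)ccc1O`: in this assay compound 2 gives 48%.
Compound 3, `COc1cc(/C=C/C(=O)c2cccc(NC(=O)c3cccs3)c2)ccc1O`: in this assay compound 3 gives 80%.

Compound 3 stands highest of the three; the step to it from compound 1 is a number 29 percentage points higher from compound 1 to compound 3 (beyond the scatter), and from compound 2 it is a number 32 percentage points higher from compound 2 to compound 3 (beyond the scatter). Between compound 1 and compound 2 the step is a number 3 percentage points lower from compound 1 to compound 2 (within the scatter), so the isopropyl and phenyl amides sit at the same level.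

Compound 4, `COc1cc(/C=C/C(=O)c2cccc(NC(C)=O)c2)ccc1O`, is not yet measured. It differs from compound 3 in one place: methyl in place of thiophen-2-yl on a carbonyl carbon. Going by the values given here, two measured steps bear on this. The gain from compound 1 to compound 3 shows that the thiophen-2-yl group is worth a modest rise over a small alkyl group, and the gain from compound 2 to compound 3 shows a similar rise over phenyl. Removing the thiophen-2-yl group in favour of methyl is therefore expected to undo that rise, giving a drop of a number 30 percentage points lower from compound 3 to compound 4 (beyond the scatter) in this assay. Compound 4 is thus estimated at 50%, in the range 35% to 65%.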

Compound 4, a percentage reported as inhibition, at one concentration (the size of the read-out at that concentration, not a potency): 15%
Estimate against measurement, compound 4: 35 percentage points above; the whole stated range lies above it.
By their numbers in this assay, from the lowest: compound 4; then compounds 2 and 1 (each within the scatter of the next); then compound 3.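

The new compound shows that the level shared by the isopropyl and phenyl amides was not a floor for this position, since methyl on the carbonyl carbon sits well under both in this assay: the step is a number 36 percentage points lower from compound 1 to compound 4 (beyond the scatter) against isopropyl and a number 33 percentage points lower from compound 2 to compound 4 (beyond the scatter) against phenyl. The thiophen-2-yl group therefore did not simply stand out from a flat baseline, and its replacement by methyl gives a number 65 percentage points lower from compound 3 to compound 4 (beyond the scatter), the widest step in this small set. The group on this carbonyl carbon thus matters in more than one direction, with the acetamido compound at the low end and the ((thiophen-2-yl)carbonyl)amino compound at the high end, while isopropyl and phenyl lie level with each other in the middle.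

No supporting data bear on why methyl lies so far under the other groups, so the result stands without an explanation. The compounds shown also leave open where an ethyl or cyclopropyl group, or a furan-2-yl ring in place of the thiophen-2-yl ring, would fall, and whether the order seen at one concentration would hold across a full concentration range.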